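The source may report more compounds than this note shows. Statements on the series, on what has been measured and on what is new or still open speak of the compounds shown alone.

Series notes, cytotoxicity branch. Three compounds of the shared core have been run in an ADME assay on Vero cells (Chlorocebus sabaeus) for cytotoxicity (a lower number here means that less compound is tolerated, a higher number that more compound is tolerated), so far: compound 1 `C/C(CN1CCN(c2nc(=O)c3cc(C(F)(F)F)cc([N+](=O)[O-])c3s2)CC1)=N\OCc1ccccc1`, compound 2 `CON=C1CCC(CN2CCN(c3nc(=O)c4cc(C(F)(F)F)cc([N+](=O)[O-])c4s3)C[C@H]2C)CC1` and compound 3 `CCON=C1CCC(CN2CCN(c3nc(=O)c4cc(C(F)(F)F)cc([N+](=O)[O-])c4s3)[C@H](C)C2)CC1`. In this assay compound 1 reaches only the limit of > 64 ug/mL and gives no number. Compound 2 likewise stops at the limit, > 64 ug/mL. Compound 3 also sits at the limit, > 64 ug/mL, so nothing beyond that is known about where it stands. The whole picture is the limit of > 64 ug/mL in this assay, at which 3 of the 3 values shown sit.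

Compound 4 `CCON=C1CCC(CN2CCN(c3nc(=O)c4cc(C(F)(F)F)cc([N+](=O)[O-])c4s3)[C@@H](C)C2)CC1` is the next member to be measured. Compared with compound 3, (the two compounds have the same atoms and bonds; at least one stereo element is drawn with a configuration in one of them and without one in the other: 1 of 3 stereo elements differ; a stereocentre at a saturated ring carbon is drawn R in compound 3 and S in compound 4). For the measured compounds named here, no measured pair isolates such a stereo change, so no step beyond the scatter is expected, a step that the limit leaves unreadable from compound 3 to compound 4. For compound 4 the expected value in this assay is 80 ug/mL, with a range from 40 ug/mL to 160 ug/mL, most likely again reported only as a limit.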

Compound 4, half-maximal cytotoxic concentration: > 64 ug/mL
Compound 4 gave a limit, no number (the forecaster's own chance of this, stated with the estimate: 85%); the middle value does not contradict the limit.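

No step can be read from compound 3 to compound 4 in this assay, as both values are limits: the limit of > 64 ug/mL in this assay, at which 4 of the 4 values shown sit. Left open is whether the R or S stereocentre at the saturated ring carbon matters at all, and where any of the four compounds lies numerically.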